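The source may hold more compounds than are shown below. What is called first, only, known or untested is meant among the compounds shown, and "the series" means these compounds.

Working notes on the series. The shared core is that of compound 1 `C/C(=N\NC(=O)c1ccncc1)C(=O)Nc1ccc(F)cc1`. In an ADME assay on HepG2 cells (Homo sapiens) for cytotoxicity, read by MTT assay (on this read-out higher numbers stand for weaker inhibition and lower numbers for stronger inhibition), compound 1 gives > 50000 nM, which is a limit of the assay and not a number. Compound 2 `C/C(=N\NC(=O)c1ccncc1)C(=O)Nc1ccc(C(F)(F)F)cc1` carries trifluoromethyl in place of fluoro on an aromatic carbon; in this assay compound 2 likewise gives > 50000 nM, again a limit rather than a number. The step that the two limits leave unreadable from compound 1 to compound 2 is therefore of no readable size. Both recorded values sit at the same limit (the limit of > 50000 nM in this assay, at which 2 of the 2 values shown sit). Compound 3 `C/C(=N\NC(=O)c1ccncc1)C(=O)Nc1cccc(Cl)c1` differs from compound 1 by 3-chlorophenyl in place of 4-fluorophenyl on an amide-type nitrogen. Among the compounds with values here, no measured step bears directly on this change; the only step recorded, from compound 1 to compound 2, cannot be sized, so it offers no direction either way. With both values at the limit, no step beyond the scatter is expected in this assay from compound 1 to compound 3, and the most likely outcome is once more a limit. Compound 3 is thus expected near 60000 nM, in the range 20000 nM to 200000 nM. That estimate amounts to an expected step that the limit leaves unreadable from compound 1 to compound 3.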

Compound 3, half-maximal inhibitory concentration: > 50000 nM
Compound 3 gave a limit, no number; the forecaster's own chance of this, stated with the estimate: 80%; the middle value is on the limit's open side.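

No step can be read between compound 1 and compound 3 in this assay, since both results are limits and not numbers: the limit of > 50000 nM in this assay, at which 3 of the 3 values shown sit.

The compounds shown leave open how compound 1, compound 2 and compound 3 compare in this assay, and whether any change to the shared core would give a readable number there.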